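Swapping an ester side chain for isopropyl in an amide series

The source may report more compounds than this note shows. Statements on the series, on what has been measured and on what is new or still open speak of the compounds shown alone.

Compound 1, `O=C(CN(c1ncnc2c1ncn2C1CCCCO1)C1CC1)NCC(=O)OCc1ccccc1`: 40.4%
Compound 2, `O=C(CN(c1ncnc2c1ncn2C1CCCCO1)C1CC1)N[C@@H](CO)C(=O)OCc1ccccc1`: 46.7%
Compound 3, `O=C(CN(c1ncnc2c1ncn2C1CCCCO1)C1CC1)N[C@@H](CC(=O)OCc1ccccc1)C(=O)OCc1ccccc1`: 38.2%

Measured in a functional assay on the whole organism (Tail, strain ICR) with Mus musculus as the target, in the tail flick test, with a stated time of 60 min, at a dose of 25 umol/kg by the oral route (on this read-out lower numbers stand for a weaker effect and higher numbers for a stronger effect at the one dose given), compound 3 gives the lowest of the three numbers, yet the step of a number 2.2 percentage points lower from compound 1 to compound 3 (within the scatter) and the step of a number 8.5 percentage points lower from compound 2 to compound 3 (within the scatter) both lie within the scatter, so the three cannot be told apart. Compound 4, `CC(C)C[C@H](NC(=O)CN(c1ncnc2c1ncn2C1CCCCO1)C1CC1)C(=O)OCc1ccccc1`, differs from compound 3 by isopropyl in place of benzyloxycarbonyl on a saturated chain carbon, two bonds along the chain from an amide-type nitrogen and a carbonyl carbon. For the measured compounds named here, the only earlier change at that place, from hydroxy to benzyloxycarbonyl, moved this assay by a number 8.5 percentage points lower from compound 2 to compound 3 (within the scatter), and the step of a number 6.3 percentage points higher from compound 1 to compound 2 (within the scatter) was equally small. Going by the values given here, no measured step therefore suggests a shift beyond the scatter, and compound 4 is expected to change by a number 2.8 percentage points higher from compound 3 to compound 4 (within the scatter). The estimate for compound 4 is 41%, between 28% and 55%.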

Compound 4, a percentage reported as activity, at one dose (the size of the read-out at that dose, not a potency): 34.2%
Compound 4: the middle estimate sits 6.8 percentage points above what was measured; the measured number falls inside the stated range.
By their numbers in this assay, from the lowest: compounds 4, 3, 1 and 2 (each within the scatter of the next, the first and the last beyond it).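

In this assay, isopropyl in place of benzyloxycarbonyl gives a number 4 percentage points lower from compound 3 to compound 4 (within the scatter) and leaves the two compounds indistinguishable, and isobutyl in place of hydrogen likewise gives a number 6.2 percentage points lower from compound 1 to compound 4 (within the scatter) in this series. Isopropyl in place of hydroxy, however, gives a number 12.5 percentage points lower from compound 2 to compound 4 (beyond the scatter) and is the only step so far beyond the scatter, so changes at this position can separate compounds on this read-out, though only modestly. As far as these compounds go, whether an amine or a carboxylic acid at this place would widen that gap stays open. Nothing measured here gives a reason for the difference.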